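Chain lengthening on the amide arm: compound 3 to compound 4

This account rests on a few compounds, and the source may have more. Where it says the series, first, only, none or still open, it means among the compounds named here.

Measured compounds in a functional assay on NCI-H1299 cells (Homo sapiens) for inhibition, read by CCK-8 assay, with a stated time of 72 h, tested at 10 uM; on this read-out higher numbers stand for a stronger effect at the one concentration tested and lower numbers for a weaker effect:
compound 1 `CN(C)C(=O)c1cc2cnc(Nc3ccc(S(=O)(=O)NCCCCN=C=S)cc3)nc2n1C1CCCC1`, 72.7%
compound 2 `CN(C)C(=O)c1cc2cnc(Nc3ccc(S(=O)(=O)NCCCCCN=C=S)cc3)nc2n1C1CCCC1`, 83.4%
compound 3 `CN(C)C(=O)c1cc2cnc(Nc3ccc(C(=O)NCCCN=C=S)cc3)nc2n1C1CCCC1`, 91.2%

Compound 3 stands at the top of these three numbers. One of the two steps that lead up to it lies beyond the scatter, a number 18.5 percentage points higher from compound 1 to compound 3 (beyond the scatter), while the other lies within it, a number 7.8 percentage points higher from compound 2 to compound 3 (within the scatter), so compound 2 and compound 3 cannot be told apart on this read-out.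

Compound 4 `CN(C)C(=O)c1cc2cnc(Nc3ccc(C(=O)NCCCCN=C=S)cc3)nc2n1C1CCCC1` differs from compound 3 by a group of 4 heavy atoms (2 carbon, 1 nitrogen, 1 sulfur; no ring) in place of a group of 3 heavy atoms (1 carbon, 1 nitrogen, 1 sulfur; no ring), on a saturated chain carbon, three bonds along the chain from an amide-type nitrogen.

Within the data shown here, one measured step bears on this change: the same lengthening of the chain by one carbon on the sulfonamide arm, a number 10.7 percentage points higher from compound 1 to compound 2 (beyond the scatter). That step rose beyond the scatter, but the number for compound 3 already sits close to the top of the scale, leaving little room. The expected step is therefore small and upward, a number 2.8 percentage points higher from compound 3 to compound 4 (within the scatter), and may well fall within the scatter. Compound 4 is expected to give 94% in this assay, within a range of 86% to 99%.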

Compound 4, a percentage reported as inhibition, at one concentration (the size of the read-out at that concentration, not a potency): 74.2%
Compound 4: the middle estimate sits 19.8 percentage points above what was measured, outside the stated range (below it).
By their numbers in this assay, from the lowest: compounds 1, 4, 2 and 3 (each within the scatter of the next, the first and the last beyond it).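

In this assay, the one-carbon lengthening has no single direction: on the amide arm, the result is a number 17 percentage points lower from compound 3 to compound 4 (beyond the scatter), whereas the same change raised the number on the sulfonamide arm. The outcome of this change therefore depends on the arm that carries the chain: the same change on two cores in this assay, a number 10.7 percentage points higher (beyond the scatter) from compound 1 to compound 2 and a number 17 percentage points lower (beyond the scatter) from compound 3 to compound 4, 27.7 percentage points apart, beyond the scatter of two such steps Set against the sulfonamide arm, the steps are a number 9.2 percentage points lower from compound 2 to compound 4 (within the scatter) and a number 1.5 percentage points higher from compound 1 to compound 4 (within the scatter), so compound 4 cannot be told apart from either sulfonamide compound on this read-out.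

The compounds shown leave open whether a longer chain on the amide arm would lower the number further, and how a sulfonamide arm with the shorter chain of compound 3 would read. Three points per arm would be needed before any trend with chain length could be described, and each arm here has at most two.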